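The source may report more compounds than this note shows. Statements on the series, on what has been measured and on what is new or still open speak of the compounds shown alone.

Compound 1, `CCC(C)NC(=C\C(=O)/C=C/c1ccc(OC(C)=O)c(OC)c1)/C=C/c1ccc(OC(C)=O)c(OC)c1`, in an ADME assay on Caco-2 cells (Homo sapiens) for inhibition, read by MTT assay, with a stated time of 72 h (on this read-out lower numbers stand for stronger inhibition and higher numbers for weaker inhibition), gives > 25000 nM, which is a limit of the assay and not a number.
Compound 2, `C=CCNC(=C\C(=O)/C=C/c1ccc(O)c(OC)c1)/C=C/c1ccc(O)c(OC)c1`, in this assay gives > 25000 nM, again a limit of the assay.
Compound 3, `COc1cc(/C=C/C(=O)/C=C(/C=C/c2ccc(OC(C)=O)c(OC)c2)NCC(C)C)ccc1OC(C)=O`, in this assay gives > 25000 nM, also a limit.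

All three measured compounds therefore stand at the limit of > 25000 nM in this assay, at which 3 of the 3 values shown sit, and compound 2 is known only as a limit, not as a number. Within the data shown here, the one step that can be read between them, a step that the two limits leave unreadable from compound 1 to compound 3, has no readable size, since both ends are limits.

Compound 4, `COc1cc(/C=C/C(=O)/C=C(/C=C/c2ccc(O)c(OC)c2)NC2CCCCC2)ccc1O`, is the compound still to be measured in this assay. It differs from compound 2 in one place: cyclohexyl in place of allyl on an amine nitrogen. Among the measured compounds shown here, no measured step involves an allyl or a cyclohexyl group, so there is no direct precedent for this change. For the measured compounds named here, the only available step is the unreadable one from compound 1 to compound 3, which shows merely that a change of the amine substituent between two acyclic groups left both compounds at the limit.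

On this basis the step that the limit leaves unreadable from compound 2 to compound 4 is expected to stay within the scatter, with compound 4 most likely remaining at the limit. Compound 4 is estimated at 30000 nM, in the range 12000 nM to 80000 nM.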

Compound 4, half-maximal inhibitory concentration: > 25000 nM
Compound 4: a limit, no number; the forecaster's own chance of this, stated with the estimate: 80%; the middle value does not contradict the limit.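

Compound 4, like compound 2, is known only as a limit, so no step can be read from compound 2 to compound 4 in this assay. The compounds shown leave open whether any change of the group on the amine nitrogen shifts the read-out, since all of them stand at the same place: the limit of > 25000 nM in this assay, at which 4 of the 4 values shown sit.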